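Carbonate removal toward a free alcohol in an antiproliferative series

The compounds below may be only part of what the source reports. "The series", "measured", "known", "first", "only" and "open" are said of these compounds alone.

Measured so far:
compound 1: `CSc1cnc2ccccc2c1[Se]CC#CCCl`, 1.7 ug/mL
compound 2: `CCOC(=O)OCC#CCSc1c(SC)cnc2ccccc12`, 13.2 ug/mL

In a functional assay on CCRF-CEM cells (Homo sapiens) for antiproliferative activity, with a stated time of 72 h (a lower number here means a stronger inhibitor, a higher number a weaker inhibitor), compound 2 gives 13.2 ug/mL, while compound 1 gives 1.7 ug/mL; compound 2 carries the higher number of the two, and the gap to compound 1 lies beyond the scatter. Compound 3, `CSc1cnc2ccccc2c1SCC#CCO`, is not yet measured. It differs from compound 2 in one place: hydrogen in place of ethoxycarbonyl on an oxygen on a saturated carbon. For the measured compounds named here, no measured pair isolates this change, so the expectation rests on compound 2 alone. The step from compound 2 to compound 3 is expected to be a modest lowering of the number, a 1.7-fold lower number from compound 2 to compound 3 (0.22 log units; within the scatter), not far beyond the scatter. For compound 3 the estimate is 8 ug/mL, with a range from 3 ug/mL to 25 ug/mL.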

Compound 3, concentration for 50% inhibition: 2.3 ug/mL
Estimate against measurement, compound 3: 3.5-fold (0.54 log units) above, outside the stated range (below it).
By their numbers in this assay, from the lowest: compounds 1 and 3 (each within the scatter of the next); then compound 2.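

In this assay hydrogen in place of ethoxycarbonyl on this oxygen gives a 5.7-fold lower number from compound 2 to compound 3 (0.76 log units; beyond the scatter) and so marks the carbonate as a place where the number responds beyond the scatter. The step of a 1.4-fold higher number from compound 1 to compound 3 (0.13 log units; within the scatter) lies within the scatter, which puts the free alcohol of compound 3 level with the chlorine- and selenium-bearing group of compound 1. Nothing measured here speaks to the cause of either step.

Going by these compounds, whether an amine, a methyl ether or a carboxylic acid at this place keeps the number of compound 3 stays open. Also open, on these data alone, is how selenium for sulfur and chlorine for hydroxy each contribute, since the two changes are taken together in this pair.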